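The source may hold more compounds than are shown below. What is called first, only, known or untested is meant among the compounds shown, and "the series" means these compounds.

Measured in a functional assay on MCF7 cells (Homo sapiens) for cytotoxicity, read by MTT assay, with a stated time of 72 h; a lower number here means a stronger inhibitor, a higher number a weaker inhibitor:
- compound 1 `N#Cc1ccc(/C=N/NC(=O)Nc2cc3c(Nc4ccc(F)c(Cl)c4)ncnc3cc2O[C@H]2CCOC2)cc1`: "not determined" (no result reported)
- compound 2 `O=C(N/N=C/c1ccc([N+](=O)[O-])cc1)Nc1cc2c(Nc3ccc(F)c(Cl)c3)ncnc2cc1O[C@H]1CCOC1`: "not active" (no number reported)
- compound 3 `COc1cc(/C=N/NC(=O)Nc2cc3c(Nc4ccc(F)c(Cl)c4)ncnc3cc2O[C@H]2CCOC2)cc(OC)c1OC`: 26500 nM

Among the measured compounds shown here, compound 3 holds the only number, so it cannot be ranked against either neighbour. Compound 1 is recorded as "not determined" (no result reported), and compound 2 as "not active" (no number reported). For the measured compounds named here, no measured step between any two compounds is available to size a change of aryl group.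

The next compound to be tested is compound 4 `O=C(N/N=C/c1ccc(O)cc1O)Nc1cc2c(Nc3ccc(F)c(Cl)c3)ncnc2cc1O[C@H]1CCOC1`, which carries 2,4-dihydroxyphenyl in place of 3,4,5-trimethoxyphenyl on a carbon with a double bond to nitrogen. The expectation rests on compound 3 alone, at 26500 nM, and no step beyond the usual scatter is expected in this assay. The estimated change is a 1.5-fold lower number from compound 3 to compound 4 (0.17 log units; within the scatter). The outcome for compound 2 leaves some chance that no number is obtained.

For compound 4 the estimated value is 18000 nM, with an expected range from 5000 nM to 50000 nM.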

Compound 4, half-maximal inhibitory concentration: 5350 nM
Beside the measured number, compound 4's estimate is 3.4-fold (0.53 log units) above it; low and high end bracket the measured number.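

In this assay, the group on the carbon with a double bond to nitrogen now has a first measured effect: 2,4-dihydroxyphenyl in place of 3,4,5-trimethoxyphenyl gives a 5.0-fold lower number from compound 3 to compound 4 (0.69 log units; beyond the scatter). The entering group has fewer heavy atoms and carries hydrogen-bond donors, whereas the leaving group carries none, so this single step does not separate those differences from one another. Nothing available accounts for the step. Steps involving compound 1 and compound 2 cannot be read, so the effect of the nitrile and nitro groups at this position stays unsized. Going by these compounds, it also remains open whether a phenyl with a single hydroxyl, or with an amine or a carboxylic acid in its place, would hold or extend the lower number seen for compound 4.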